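A bromo swap at the limit of the assay

The source may hold more compounds than are shown below. What is called first, only, known or untested is meant among the compounds shown, and "the series" means these compounds.

Compound 1 `Cc1ccc(/C=C2\C(=O)c3ccccc3OC2c2ccccc2)cc1`: > 1000000 nM, a limit
Compound 2 `O=C1/C(=C\c2ccc(Cl)cc2)C(c2ccccc2)Oc2ccccc21`: > 1000000 nM, a limit

In a functional assay on NALM-6 cells (Homo sapiens) for cytotoxicity, read by MTT assay, with a stated time of 46 h (on this read-out higher numbers stand for weaker inhibition and lower numbers for stronger inhibition), compound 2 gives no number, only the limit > 1000000 nM. This is the limit of > 1000000 nM in this assay, at which 2 of the 2 values shown sit. Compound 3 `O=C1/C(=C\c2ccc(Br)cc2)C(c2ccccc2)Oc2ccccc21` carries bromo in place of chloro on an aromatic carbon. For the measured compounds named here, the one measured step, a step that the two limits leave unreadable from compound 1 to compound 2, has no readable size and gives no direction. The expected step is therefore a number no higher from compound 2 to compound 3 (the limit leaves the size open), with no change beyond the scatter in either direction. For compound 3 the estimate is 1000000 nM, with an expected range of 200000 nM to 2000000 nM, and the assay may well report only a limit again.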

Compound 3, half-maximal inhibitory concentration in the NALM-6 assay: > 1000000 nM
Compound 3 ended at the assay's limit; the forecaster's own chance of this, stated with the estimate: 75%; the middle value sits exactly at the limit.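

In the NALM-6 assay compound 3 gives > 1000000 nM as a limit of the assay. Compound 1, compound 2 and compound 3 each give only a limit, so no step between them can be read: the limit of > 1000000 nM in the NALM-6 assay, at which 3 of the 3 values shown sit.

In a physicochemical assay for lipophilicity, read by HPLC (on this read-out higher numbers stand for higher lipophilicity and lower numbers for lower lipophilicity), compound 2 gives 4.53 and compound 3 gives 4.71 and the step reads a number 0.18 log units higher from compound 2 to compound 3 (within the scatter) here.

The compounds shown leave open how methyl, chloro and bromo compare in the NALM-6 assay since none gives an actual number.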